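This account rests on a few compounds, and the source may have more. Where it says the series, first, only, none or still open, it means among the compounds named here.

In a functional assay on CNE-2 cells (Homo sapiens) for inhibition, read by MTT assay, with a stated time of 72 h (a lower number here means a stronger inhibitor, a higher number a weaker inhibitor), compound 1 (`CNC(=O)CCCCCCCn1nc(-c2cnc3[nH]ccc3c2)c2c(N)ncnc21`) gives 8990 nM. Compound 2 (`Nc1ncnc2c1c(-c1cnc3[nH]ccc3c1)nn2CC(=O)NO`) gives > 150000 nM, which is a limit and not a number. Compound 3 (`Nc1ncnc2c1c(-c1cnc3[nH]ccc3c1)nn2CCCCC(=O)NO`) gives > 150000 nM, again only a limit. Compound 3 thus stands at the limit of > 150000 nM in this assay, at which 2 of the 3 values shown sit.

Compound 4 (`Nc1ncnc2c1c(-c1cnc3[nH]ccc3c1)nn2CCCCCC(=O)NO`) differs from compound 3 by (hydroxycarbamoyl)methyl in place of hydroxycarbamoyl on a saturated chain carbon, four bonds along the chain from an aromatic nitrogen.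

The closest evidence is a step that the two limits leave unreadable from compound 2 to compound 3, so an earlier change of chain length within this hydroxycarbamoyl series gives no measurable size. Among the measured compounds shown here, the large steps, an at least 16-fold higher number from compound 1 to compound 2 (1.22 log units; beyond the scatter) and an at least 16-fold higher number from compound 1 to compound 3 (1.22 log units; beyond the scatter), show only that compound 1 reads stronger than both, and they change the chain end as well as its length. A modest move towards a lower number is therefore expected, though compound 4 may well remain at the limit. The expected step is an at least 3.0-fold lower number from compound 3 to compound 4 (0.47 log units; beyond the scatter). Compound 4 is estimated at 50000 nM, with an expected range from 8000 nM to 150000 nM.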

Compound 4, half-maximal inhibitory concentration: > 50000 nM
Compound 4 ended at the assay's limit (the forecaster's own chance of this, stated with the estimate: 45%); the middle value sits exactly at the limit.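

Compound 4, with its 4-(hydroxycarbamoyl)butyl chain, still gives a limit and not a number, so this lengthening has not yet brought the hydroxycarbamoyl series to a measurable value: the limit of > 50000 nM in this assay, at which 1 of the 4 values shown sits.

As far as these compounds go, the steps among compound 2, compound 3 and compound 4 cannot be read, as each has a limit at both ends, so the size of the chain-length effect remains unknown. Among the compounds shown here, the one readable step is an at least 5.5-fold higher number from compound 1 to compound 4 (0.74 log units; beyond the scatter), and it changes chain length and chain end together.

From the compounds shown here alone, what a longer hydroxycarbamoyl chain, matching the length of the chain in compound 1, would read stays open. So does the part played by the chain end alone, which a methylcarbamoyl group or a carboxylic acid on the chain of compound 4 would separate from chain length.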